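A few compounds are considered here, and "the series" means these few. Any claim that something is new, unique, unknown or untested is made for them only; others in the source may bear on it.

Compound 1 `O=C(N/N=C/c1cc(I)cc(I)c1O)c1ccc(F)cc1` and compound 2 `O=C(N/N=C/c1cc(I)cc(I)c1O)c1ccc(Cl)cc1` are built on one core, while compound 3 `O=C(NNC(=O)c1cc(I)cc(I)c1O)c1ccc(F)cc1` and compound 4 `O=C(NNC(=O)c1cc(I)cc(I)c1O)c1ccc(Cl)cc1` are built on another; how the two cores differ is not broken down here. In a functional assay on HepG2 cells (Homo sapiens) for cytotoxicity, with a stated time of 24 h (a lower number here means a stronger inhibitor, a higher number a weaker inhibitor), compound 1 gives 12100 nM, compound 2 gives 14800 nM and compound 3 gives 87000 nM. Compound 3 thus shows the highest number of the three measured compounds, with compound 2 nearest to it and compound 1 furthest from it. The step of a 1.2-fold higher number from compound 1 to compound 2 (0.09 log units; within the scatter) came from the change (chloro in place of fluoro on an aromatic carbon). The difference between compound 3 and compound 4 is the same change, made at the same place: chloro in place of fluoro on an aromatic carbon. Because the measured step of a 1.2-fold higher number from compound 1 to compound 2 (0.09 log units; within the scatter) was small, compound 4 is expected to sit close to compound 3, and the step of a 1.1-fold higher number from compound 3 to compound 4 (0.06 log units; within the scatter) is what is expected here. In this assay compound 4 is therefore estimated at 100000 nM, with the likely range expected to run from 40000 nM to 250000 nM.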

Compound 4, half-maximal inhibitory concentration: 48700 nM
Beside the measured number, compound 4's estimate is 2.1-fold (0.31 log units) above it; the measured number falls inside the stated range.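

In this assay, chloro in place of fluoro on the second core gives a 1.8-fold lower number from compound 3 to compound 4 (0.25 log units; within the scatter), a step that, like the earlier one on the first core, stays within the usual scatter. Set side by side, the two steps cannot be told apart: the same change on two cores in this assay, a 1.2-fold higher number (0.09 log units; within the scatter) from compound 1 to compound 2 and a 1.8-fold lower number (0.25 log units; within the scatter) from compound 3 to compound 4, 2.2-fold (0.34 log units) apart, within the scatter of two such steps. Among the compounds shown here, this shows that, for this one change, the two cores agree in giving no step that can be read beyond the scatter, but it does not show that they would respond alike to a change with a larger step, and with only one pair on each core it gives no reliable direction for the change.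

The compounds shown leave open how a methoxy group, a nitrile or an amine in the place of the halogen would behave, and whether such steps would carry from one core to the other. They also leave open what happens when either iodine on the hydroxyl-bearing ring gives way to hydrogen or to a smaller halogen such as bromine.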